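The source may report more compounds than this note shows. Statements on the series, on what has been measured and on what is new or still open speak of the compounds shown alone.

Working notes on the series. In a functional assay on THP-1 cells (Homo sapiens) for cytotoxicity, read by MTT assay, with a stated time of 24 h (on this read-out lower numbers stand for stronger inhibition and higher numbers for weaker inhibition), compound 1 `COc1cc(/C=C2\CN(C)C/C(=C\c3ccccc3F)C2=O)cc(OC)c1OC` gives 640 nM. Compound 2 `COc1cc(/C=C2\CN(C)C/C(=C\c3ccc(F)cc3)C2=O)cc(OC)c1OC` gives 6130 nM in this assay; the step is a 9.6-fold higher number from compound 1 to compound 2 (0.98 log units; beyond the scatter). Among the compounds with values here, on the two numbers so far, compound 2 stands highest, with compound 1 the only neighbour and well apart from it. Compound 3 `COc1cc(/C=C2\CN(C)C/C(=C\c3ccc(Cl)cc3Cl)C2=O)cc(OC)c1OC` is not yet measured; the change from compound 2 is 2,4-dichlorophenyl in place of 4-fluorophenyl on a double-bonded chain carbon bound to a double-bonded ring carbon. Within the data shown here, only the step from compound 1 to compound 2 bears on this change, and it concerns fluorine alone; nothing measured concerns chlorine, nor an aryl carrying two halogens. Since a 2-halogen pattern was tied to the lower number of compound 1 at 640 nM, a downward step from compound 2 is expected, but with wide uncertainty: the step is expected to be a 4.1-fold lower number from compound 2 to compound 3 (0.61 log units; beyond the scatter). Compound 3 is estimated at 1500 nM, in the range 400 nM to 6000 nM.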

Compound 3, half-maximal inhibitory concentration: 5020 nM
Compound 3: the middle estimate sits 3.3-fold (0.52 log units) below what was measured; measured number inside the range.
By their numbers in this assay, from the lowest: compound 1; then compounds 3 and 2 (each within the scatter of the next).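

In this assay, the step of a 1.2-fold lower number from compound 2 to compound 3 (0.09 log units; within the scatter) shows that replacing 4-fluorophenyl with 2,4-dichlorophenyl on a double-bonded chain carbon bound to a double-bonded ring carbon leaves the read-out within the scatter, while the step of a 7.8-fold higher number from compound 1 to compound 3 (0.89 log units; beyond the scatter) sets the new group well apart from 2-fluorophenyl. Among these three compounds, only compound 1 stands apart, so the low number at this position belongs to 2-fluorophenyl and does not extend to 2,4-dichlorophenyl. No measurement is available to explain this difference.

The compounds shown leave open whether the loss follows from chlorine in place of fluorine or from the second halogen, as 2-chlorophenyl and 2,4-difluorophenyl would separate these two changes. They also leave open how a plain phenyl or a 2-methoxyphenyl would read at this position.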